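Extending the nitrate chain in a coumarin-based inhibitor

A few compounds are considered here, and "the series" means these few. Any claim that something is new, unique, unknown or untested is made for them only; others in the source may bear on it.

Measured so far:
Compound 1, `Cc1c(C)c2ccc(OCC3CCN(Cc4cccc(OCCCO)c4)CC3)cc2oc1=O`: 550 nM in an assay for inhibition of Amine oxidase [flavin-containing] A (Homo sapiens), read by fluorescence, using microsomes, with a stated time of 30 min; a lower number here means a stronger inhibitor, a higher number a weaker inhibitor
Compound 2, `Cc1c(C)c2ccc(OCC3CCN(Cc4cccc(CO[N+](=O)[O-])c4)CC3)cc2oc1=O`: 230 nM in this assay

Among these two compounds, compound 2 has the lower number, and its only neighbour is compound 1, which stands a 2.4-fold lower number from compound 1 to compound 2 (0.38 log units; beyond the scatter) when read the other way, a modest gap that lies beyond the scatter.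

The next compound, compound 3, `Cc1c(C)c2ccc(OCC3CCN(Cc4cccc(OCCCO[N+](=O)[O-])c4)CC3)cc2oc1=O`, differs from compound 2 in one place: 3-(nitrooxy)propoxy in place of (nitrooxy)methyl on an aromatic carbon. The nitrooxy group is kept, but it now sits at the end of a three-carbon chain attached through an oxygen to the ring.

Within the data shown here, only one measured step bears on this change, and only indirectly. The step of a 2.4-fold lower number from compound 1 to compound 2 (0.38 log units; beyond the scatter) removed a three-carbon oxygen-linked chain and introduced a nitrooxy group at the same time, so it cannot separate the two effects. Compound 3 keeps both features. The expected outcome in this assay is therefore a step of a 1.5-fold higher number from compound 2 to compound 3 (0.18 log units; within the scatter), a small shift toward a higher number that may not exceed the scatter. Compound 3 is estimated at 350 nM, with a likely range from 120 nM to 1000 nM.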

Compound 3, half-maximal inhibitory concentration: 1200 nM
The estimate for compound 3 lay 3.4-fold (0.54 log units) below the measured number; the measured number lies above the stated range.
By their numbers in this assay, from the lowest: compound 2; then compound 1; then compound 3.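

In this assay the nitrooxy end group does not bring the same result wherever it sits: moving from (nitrooxy)methyl to 3-(nitrooxy)propoxy on this aromatic carbon gives a 5.2-fold higher number from compound 2 to compound 3 (0.72 log units; beyond the scatter) and so reverses the earlier gain and more. Compound 1 and compound 3 carry the same chain and differ only at its end, where nitro replaces hydrogen on the oxygen, and this single change gives a 2.2-fold higher number from compound 1 to compound 3 (0.34 log units; beyond the scatter) in the opposite direction to a 2.4-fold lower number from compound 1 to compound 2 (0.38 log units; beyond the scatter), the step that altered the chain as well, so on this chain the nitrooxy end goes with a weaker inhibitor. No measurement available here gives a reason for either shift.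

On these data alone, the step to compound 3 lengthens the chain and adds an oxygen link to the ring together, so the share of each in the higher number remains unknown. Also open, as far as these compounds go, is how the number would respond to a 2-(nitrooxy)ethoxy group, to a longer chain ending in nitrooxy, or to an amine at the end of the three-carbon chain.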